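The source may hold more compounds than are shown below. What is called first, only, known or untested is meant among the compounds shown, and "the series" means these compounds.

Three compounds share one core and were run in a functional assay on HEK293 cells for activation of melanin-concentrating hormone receptor 1 (Homo sapiens), read by inositol phosphate accumulation; a higher number here means that more compound is needed for the effect, a lower number that less compound is needed. Compound 1 `CCCc1ccc(/C=C/C(=O)Nc2ccc3nc(CCC)cc(N)c3c2)cc1` gives 3600 nM. Within the data shown here, compound 3 `CCCc1cc(N)c2cc(NC(=O)/C=C/c3ccc(C(C)(C)C)cc3)ccc2n1` gives 910 nM, and the only one-place step among the measured compounds, a 4.0-fold lower number from compound 1 to compound 3 (0.60 log units; beyond the scatter), lies on the outer phenyl ring. Compound 2 `CC(C)(C)c1cc(N)c2cc(NC(=O)/C=C/c3ccc(C(F)(F)F)cc3)ccc2n1` gives 29 nM, the lowest of the three numbers; compound 3 differs from it in two places at once, so their values can only be compared as they stand.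

Compound 4 `Nc1cc(C2CCCC2)nc2ccc(NC(=O)/C=C/c3ccc(C(F)(F)F)cc3)cc12` is the next candidate. Relative to compound 2 it carries cyclopentyl in place of tert-butyl on an aromatic carbon. Among the measured compounds shown here, no measured step touches this position: the one step known, a 4.0-fold lower number from compound 1 to compound 3 (0.60 log units; beyond the scatter), concerns a different ring and was modest. With nothing that speaks for a large shift, the expectation is that compound 4 stays close to compound 2, with at most a small step, a 1.6-fold higher number from compound 2 to compound 4 (0.19 log units; within the scatter). The estimate for compound 4 in this assay is therefore 45 nM, within a range from 15 nM to 150 nM.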

Compound 4, half-maximal effective concentration: 68 nM
Compound 4: the middle estimate sits 1.5-fold (0.18 log units) below what was measured; the measured number falls inside the stated range.
By their numbers in this assay, from the lowest: compound 2; then compound 4; then compound 3; then compound 1.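

Among these compounds, this is the first measured change at the aromatic carbon next to the ring nitrogen. In this assay, cyclopentyl in place of tert-butyl gives a modest step beyond the scatter (a 2.3-fold higher number from compound 2 to compound 4 (0.37 log units; beyond the scatter)), so a five-membered non-aromatic ring of carbon only can stand at this position with a limited change in the number, although the two carbon-only groups are not interchangeable here. No measurement shown here accounts for the rise in the number.

As far as these compounds go, both groups compared at this position contain only carbon and hydrogen, so the effect of a morpholine or a carboxylic acid there remains open. Also open, from the compounds shown here alone, is whether the same exchange would give a step of similar size with a group other than trifluoromethyl on the outer phenyl ring.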